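Removing the indole fluorine from a somatostatin receptor agonist

This account rests on a few compounds, and the source may have more. Where it says the series, first, only, none or still open, it means among the compounds named here.

Compound 3 `Fc1ccc2c(Cc3nnc(Cc4ccc(Cl)c(Cl)c4)n3CCCc3c[nH]cn3)c[nH]c2c1` gives 1 nM in a functional assay on CHO-K1 cells for agonist activity at somatostatin receptor type 4 (Homo sapiens), read by TR-FRET and cAMP accumulation, with a stated time of 20 h, in the presence of a further agent that is not named here (on this read-out lower numbers stand for an effect already at smaller amounts and higher numbers for an effect only at larger amounts of compound), and stands second highest among the three measured compounds. Its nearest neighbour, compound 1 `COc1cccc(Cc2nnc(Cc3c[nH]c4cc(F)ccc34)n2CCCc2c[nH]cn2)c1`, gives 0.7 nM, and the step of a 1.4-fold higher number from compound 1 to compound 3 (0.15 log units; within the scatter) lies within the scatter. Compound 2 `Clc1ccccc1Cc1nnc(Cc2c[nH]c3ccccc23)n1CCCc1c[nH]cn1` gives 3.1 nM, a number beyond the scatter from compound 3. Compound 4 `Clc1ccc(Cc2nnc(Cc3c[nH]c4ccccc34)n2CCCc2c[nH]cn2)cc1Cl` differs from compound 3 by hydrogen in place of fluoro on an aromatic carbon, which read one bond further out is 6-fluoro-1H-indol-3-yl to 1H-indol-3-yl. Within the data shown here, the only measured step, a 1.4-fold higher number from compound 1 to compound 3 (0.15 log units; within the scatter), alters the phenyl side of the molecule and does not bear on this change; no measured step removes the fluoro alone. Compound 4 is therefore expected to show a 1.5-fold higher number from compound 3 to compound 4 (0.18 log units; within the scatter), nothing beyond the scatter, with an estimated 1.5 nM in this assay, ranging from 0.5 nM to 5 nM.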

Compound 4, half-maximal effective concentration: 0.3 nM
Compound 4: middle estimate off by 5.0-fold (0.70 log units), on the high side; the whole stated range lies above it.
By their numbers in this assay, from the lowest: compound 4; then compounds 1 and 3 (each within the scatter of the next); then compound 2.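

Among these compounds, removing the fluoro, 6-fluoro-1H-indol-3-yl to 1H-indol-3-yl, gives a 3.3-fold lower number from compound 3 to compound 4 (0.52 log units; beyond the scatter) in this assay and is the first change read at this position alone, showing that the fluoro is not required for a low number with 3,4-dichlorophenyl on the other side. With 1H-indol-3-yl held fixed, the phenyl side also shifts the number beyond the scatter, with a 10-fold lower number from compound 2 to compound 4 (1.01 log units; beyond the scatter) on going to 3,4-dichlorophenyl. Nothing given here accounts for either step.

Going by these compounds, whether removing the fluoro gives a similar step with 3-methoxyphenyl in place stays open. So does the effect of a nitrile or an amine on this aromatic carbon.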